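A few compounds are considered here, and "the series" means these few. Any claim that something is new, unique, unknown or untested is made for them only; others in the source may bear on it.

Working notes on the series. Compound 2 `O=[N+]([O-])c1ccc(Nc2ccc(N3CC4CC(C3)N4)cn2)cc1` gives 1.76 nM in an assay on cell membranes for displacement of a labelled ligand from Neuronal acetylcholine receptor; alpha4/beta2 (Rattus norvegicus); on this read-out lower numbers stand for stronger inhibition and higher numbers for weaker inhibition. For the measured compounds named here, compound 1 `c1ccc(Nc2ccc(N3CC4CC(C3)N4)cn2)cc1` gives 2.66 nM in this assay, and the step of a 1.5-fold lower number from compound 1 to compound 2 (0.18 log units; within the scatter) is the only single-point change measured so far. Going by the values given here, compound 3 `O=[N+]([O-])c1ccc(Nc2cncc(N3CC4CC(C3)N4)c2)cc1` carries the same nitro-bearing ring on a differently built core and gives 0.0225 nM; no single-point step connects it to compound 2, so the two values simply stand side by side. On the three numbers in hand, compound 2 holds the second highest, with compound 1 nearest and compound 3 furthest, that gap lying beyond the scatter.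

Compound 4 `Oc1ccc(Nc2ccc(N3CC4CC(C3)N4)cn2)cc1` differs from compound 2 by hydroxy in place of nitro on an aromatic carbon. Among the compounds with values here, the one measured step that touches this position, a 1.5-fold lower number from compound 1 to compound 2 (0.18 log units; within the scatter), shows that exchanging hydrogen for nitro there moved the number only within the scatter. Within the data shown here, no measured step shows hydroxy at this position, and the pair compound 2 and compound 3 concerns the core, not this ring. The step expected is therefore a 1.7-fold higher number from compound 2 to compound 4 (0.23 log units; within the scatter), nothing beyond the scatter. Compound 4 is accordingly estimated at 3 nM, with a range from 0.8 nM to 12 nM.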

Compound 4, inhibition constant: 7.1 nM
Compound 4: middle estimate off by 2.4-fold (0.37 log units), on the low side, and the stated range covers the measured number.
By their numbers in this assay, from the lowest: compound 3; then compounds 2 and 1 (each within the scatter of the next); then compound 4.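

In this assay, the position on the six-membered aromatic ring of carbon only, para to a large group, turns out not to be indifferent to what it carries: hydrogen and nitro there lie within the scatter of each other (a 1.5-fold lower number from compound 1 to compound 2 (0.18 log units; within the scatter)), but hydroxy gives a step beyond the scatter from nitro (a 4.0-fold higher number from compound 2 to compound 4 (0.61 log units; beyond the scatter)) and from hydrogen (a 2.7-fold higher number from compound 1 to compound 4 (0.43 log units; beyond the scatter)). Both new steps run the same way and are modest, so among these three groups hydroxy is the one that separates from the other two, and the change is a shift in the number, not a loss of binding. Hydroxy is also the only one of the three that counts a hydrogen-bond donor, but this is a coincidence of counts on three compounds, and nothing measured here accounts for the shift.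

Still open, going by these compounds, is whether an amine, a methoxy group or a carboxylic acid at this position would sit with hydroxy or with hydrogen and nitro. Also open, on these data alone, is whether hydroxy in place of nitro on the core of compound 3 would give a step of similar size.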